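The source may report more compounds than this note shows. Statements on the series, on what has been measured and on what is new or still open speak of the compounds shown alone.

Values in a physicochemical assay for solubility, read by HPLC, in phosphate buffer, at pH 6.5 (on this read-out higher numbers stand for higher solubility and lower numbers for lower solubility), are as follows:
- compound 1 `COC(=O)C1=C(C)NC(c2nccs2)=NC1(C)c1ccc(F)cc1` gives 22 ug/mL
- compound 2 `COC(=O)C1=C(CN2CCC(O)C2)NC(c2nccs2)=NC1(C)c1ccc(F)cc1` gives 503 ug/mL
- compound 3 `COC(=O)C1=C(CN2CCCS2(=O)=O)NC(c2nccs2)=NC1(C)c1ccc(F)cc1` gives 125 ug/mL

Compound 3 stands second highest of the three, with a 4.0-fold lower number from compound 2 to compound 3 (0.60 log units; beyond the scatter) and a 5.7-fold higher number from compound 1 to compound 3 (0.75 log units; beyond the scatter) marking its distance from the other two. Compound 4 `COC(=O)C1=C(COC2CCOC2)NC(c2nccs2)=NC1(C)c1ccc(F)cc1` differs from it by one change: a group of 6 heavy atoms (4 carbon, 2 oxygen; one five-membered non-aromatic ring with 1 hetero atom) in place of a group of 7 heavy atoms (3 carbon, 1 nitrogen, 2 oxygen, 1 sulfur; one five-membered non-aromatic ring with 2 hetero atoms), on a saturated chain carbon bound to a double-bonded ring carbon. The closest guide is a 5.7-fold higher number from compound 1 to compound 3 (0.75 log units; beyond the scatter), a modest step. The large 23-fold higher number from compound 1 to compound 2 (1.36 log units; beyond the scatter) belongs to the 3-hydroxypyrrolidin-1-yl group of compound 2, which compound 4 lacks. The entering (oxolan-3-yl)oxy group matches the leaving group in hydrogen-bond counts and charge, so no step beyond the scatter is expected in this assay. The estimated step is a 1.3-fold lower number from compound 3 to compound 4 (0.10 log units; within the scatter). For compound 4 the expected value is 100 ug/mL, with an estimated range of 40 ug/mL to 250 ug/mL.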

Compound 4, solubility: 30 ug/mL
Compound 4: middle estimate off by 3.3-fold (0.52 log units), on the high side; measured number outside the range, below it.
By their numbers in this assay, from the lowest: compounds 1 and 4 (each within the scatter of the next); then compound 3; then compound 2.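

In this assay the (oxolan-3-yl)oxy group gives a 4.2-fold lower number from compound 3 to compound 4 (0.62 log units; beyond the scatter) and a 17-fold lower number from compound 2 to compound 4 (1.22 log units; beyond the scatter) while a 1.4-fold higher number from compound 1 to compound 4 (0.13 log units; within the scatter) stays within the scatter. At this saturated chain carbon, then, the entering and leaving groups of compound 3 and compound 4 differ clearly in the read-out despite matching hydrogen-bond counts and charge, and a group placed here need not move the number away from that of compound 1. Nothing measured here accounts for this difference. Still open, from the compounds shown here alone, is how a pyrrolidin-1-yl group without the hydroxyl would compare with the 3-hydroxypyrrolidin-1-yl group of compound 2. A morpholine at this carbon is equally untested among the compounds shown.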